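This account rests on a few compounds, and the source may have more. Where it says the series, first, only, none or still open, it means among the compounds named here.

Of the compounds shown here, three of the shared core have been measured in a functional assay on PC-3 cells (Homo sapiens) for cytotoxicity, read by sulforhodamine B assay, with a stated time of 72 h; a higher number here means a weaker inhibitor of growth, a lower number a stronger inhibitor of growth. Compound 1 `CC(=O)N1c2ccccc2CCC1C(=O)Nc1ccccc1O` carries an acetyl group on the ring nitrogen and gives 70700 nM in this assay. Compound 2 `CCCC(=O)N1c2ccccc2CCC1C(=O)Nc1cc(C(F)(F)F)cc(C(F)(F)F)c1` carries a butanoyl group on that nitrogen together with a bis(trifluoromethyl)-substituted anilide and gives 18600 nM in this assay. Compound 3 `CCCC(=O)N1c2ccccc2CCC1C(=O)Nc1ccccc1C(F)(F)F` keeps the butanoyl group but pairs it with a trifluoromethyl-substituted anilide. For compound 3 this assay reports only a limit, > 70000 nM, so no number is known for it. Among the three results that limit is the one described in the limit of > 70000 nM in this assay, at which 1 of the 3 values shown sits.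

Compound 4 `O=C(Nc1ccccc1C(F)(F)F)C1CCc2ccccc2N1C(=O)c1cccc(Cl)c1` follows compound 3 with a single change: 3-chlorophenyl in place of propyl on a carbonyl carbon, the carbonyl carbon whose other neighbour is the amide-type nitrogen in the ring. Going by the values given here, no pair among the measured compounds differs in that position, so the size of this step has no measured counterpart here.

The expectation for compound 4 is a modest gain in growth inhibition, a step of about an at least 1.7-fold lower number from compound 3 to compound 4 (0.24 log units; that floor lies within the scatter) from the limit of compound 3. Compound 4 is thus estimated at 40000 nM in this assay, with a likely range from 10000 nM to 100000 nM.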

Compound 4, concentration for 50% growth inhibition: 729 nM
Compound 4: the middle estimate sits 55-fold (1.74 log units) above what was measured, and the stated range ends above it.
By their numbers in this assay, from the lowest: compound 4; then compound 2; then compound 1.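

In this assay, exchanging propyl for 3-chlorophenyl on the carbonyl carbon whose other neighbour is the amide-type nitrogen in the ring, with the rest of the molecule unchanged, gives an at least 96-fold lower number from compound 3 to compound 4 (1.98 log units; beyond the scatter). Going by these compounds alone, the earlier compounds held no pair differing at this place, so this is the first sign that growth inhibition in this cell line responds strongly to the group carried there, and the step lies well beyond the usual scatter. The printed size is only a floor and the true step may be larger, because compound 3 is known only as a limit: the limit of > 70000 nM in this assay, at which 1 of the 4 values shown sits.

A single step cannot tell whether the aromatic ring or its chlorine carries the gain; a plain phenyl, a 4-chlorophenyl or a longer alkyl chain on that carbonyl would begin to separate these readings. From the compounds shown here alone, it also remains open whether 3-chlorophenyl gives a step of similar size when paired with a different anilide, such as the bis(trifluoromethyl)-substituted one of compound 2 or the hydroxy-bearing one of compound 1.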